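Swapping the oxazole ring for an open-chain group

This account rests on a few compounds, and the source may have more. Where it says the series, first, only, none or still open, it means among the compounds named here.

Measured so far in an in vivo ADME assay on the whole organism (plasma) for pharmacokinetics, with Rattus norvegicus as the target, at a dose of 50 mg/kg by the oral route; a higher number here means more compound in the circulation at the dose given, a lower number less compound in the circulation:
compound 1 `CC(=O)OCc1c(C)cc(C)c(NC(=O)c2sccc2S(=O)(=O)Nc2onc(C)c2Cl)c1C`: 7420 nM
compound 2 `CCCS(=O)(=O)c1cc(C)cc(C)c1NC(=O)c1sccc1S(=O)(=O)Nc1onc(C)c1Cl`: 5450 nM
compound 3 `Cc1cc(C)c(NC(=O)c2sccc2S(=O)(=O)Nc2onc(C)c2Cl)c(-c2ncco2)c1`: 134000 nM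

Compound 3, at 134000 nM, stands highest of the three, and its gaps to the other two lie beyond the scatter. The next compound to be tested in this assay is compound 4 `CO/N=C(\C)c1cc(C)cc(C)c1NC(=O)c1sccc1S(=O)(=O)Nc1onc(C)c1Cl`, which has not yet been measured. It differs from compound 3 in one place: a group of 5 heavy atoms (3 carbon, 1 nitrogen, 1 oxygen; no ring) in place of a group of 5 heavy atoms (3 carbon, 1 nitrogen, 1 oxygen; one five-membered aromatic ring with 2 hetero atoms), on an aromatic carbon. The group that enters has no ring and one double bond outside aromatic rings.

Among the measured compounds shown here, only one measured step bears on this change directly: a 25-fold higher number from compound 2 to compound 3 (1.39 log units; beyond the scatter). There the 1,3-oxazol-2-yl came in, whereas here it leaves. For the measured compounds named here, no measured step shows the incoming group itself, so the size of the change is uncertain. Compound 1 at 7420 nM and compound 2 at 5450 nM both lack the 1,3-oxazol-2-yl, and both sit far lower than compound 3. A fall is therefore expected, probably smaller than the full height of that earlier rise. The expected change is a 5.4-fold lower number from compound 3 to compound 4 (0.73 log units; beyond the scatter). For compound 4 the estimate is 25000 nM, with an expected range of 6000 nM to 100000 nM.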

Compound 4, maximal plasma concentration: 27800 nM
Compound 4: the middle estimate sits 1.1-fold (0.05 log units) below what was measured, within the range that was stated.
By their numbers in this assay, from the lowest: compounds 2 and 1 (each within the scatter of the next); then compound 4; then compound 3.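

In this assay, taking the 1,3-oxazol-2-yl off this aromatic carbon gives a 4.8-fold lower number from compound 3 to compound 4 (0.68 log units; beyond the scatter), so an open-chain group with the same counts of heavy atoms and hydrogen-bond acceptors does not match the ring. Yet the ring is not the only group here that lifts the number, since the same open-chain group, in place of propylsulfonyl, gives a 5.1-fold higher number from compound 2 to compound 4 (0.71 log units; beyond the scatter), which places compound 4 on a middle step rather than at either end of these three groups. No measurement shown gives a reason for either step.

The compounds shown leave open how another ring on this carbon, such as a thiazole or a pyridine, would compare with the 1,3-oxazol-2-yl. They also leave open where a simple amide or a methoxy group would stand against the open-chain group of compound 4.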